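The compounds below may be only part of what the source reports. "The series", "measured", "known", "first", "only" and "open" are said of these compounds alone.

Three close relatives of one small core have been measured in an assay for inhibition of histone acetyltransferase KAT2B (Homo sapiens); a lower number here means a stronger inhibitor, a higher number a weaker inhibitor. Compound 1 `O=c1cc(CO)sn1-c1ccccc1` carries a hydroxymethyl group and gives 109000 nM. Compound 2 `CC(=O)OCc1cc(=O)n(-c2ccccc2)s1` is the acetate of that alcohol, and compound 2 gives 162000 nM; the move a 1.5-fold higher number from compound 1 to compound 2 (0.17 log units; within the scatter) shows that capping the oxygen changed little. Compound 3 `Cc1csn(-c2ccccc2)c1=O` carries a plain methyl, and compound 3 gives 32000 nM, the lowest of the three numbers, with compound 1 and compound 2 both clearly higher.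

Compound 4 `COCc1csn(-c2ccccc2)c1=O` differs from compound 3 by methoxy in place of hydrogen on a saturated chain carbon bound to an aromatic carbon; read one bond further out, the methyl becomes methoxymethyl. Within the data shown here, no measured pair repeats exactly this change. Among the measured compounds shown here, the nearest precedent is the growth of the oxygen substituent from compound 1 to compound 2, which stayed within the scatter. On that basis compound 4 is expected to sit close to compound 3, with the estimated step of a 1.4-fold higher number from compound 3 to compound 4 (0.15 log units; within the scatter) not beyond the scatter. The estimate for compound 4 is therefore 45000 nM, within a range from 15000 nM to 140000 nM.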

Compound 4, half-maximal inhibitory concentration: 102000 nM
The estimate for compound 4 lay 2.3-fold (0.36 log units) below the measured number; the measured number falls inside the stated range.
By their numbers in this assay, from the lowest: compound 3; then compounds 4, 1 and 2 (each within the scatter of the next).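

Among these compounds, the change from methyl to methoxymethyl in this assay (a 3.2-fold higher number from compound 3 to compound 4 (0.50 log units; beyond the scatter)) is the first single change here to move the number beyond the usual scatter, and it moves it upward. On this saturated chain carbon bound to an aromatic carbon, adding methoxy to the plain methyl therefore weakens inhibition, whereas the earlier change on the oxygen of compound 1 did not shift the number measurably. Nothing available explains why this added methoxy raises the number.

The compounds shown leave open whether the rise follows from the oxygen itself or simply from the longer group. An ethyl group, which holds no oxygen, would help separate the two, and an amine or a carboxylic acid at this place would show how other groups behave.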